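Trimming the Benzyl Group of Compound 3

A few compounds are considered here, and "the series" means these few. Any claim that something is new, unique, unknown or untested is made for them only; others in the source may bear on it.

Of the compounds shown here, three sharing one core have been measured in a functional assay on PC-3 cells (Homo sapiens) for antiproliferative activity, read by MTT assay, with a stated time of 48 h; a higher number here means a weaker inhibitor, a lower number a stronger inhibitor. Compound 1 `COc1ccc(CN(C(=O)CSc2nc3ccccc3s2)c2cc(OC)c(OC)c(OC)c2)cc1N=[N+]=[N-]` gives 14400 nM, compound 2 `COc1ccc(CN(C(=O)CSc2nc3ccccc3s2)c2cc(OC)c(OC)c(OC)c2)cc1O` gives 2110 nM, and compound 3 `COc1ccc(CN(C(=O)CSc2nc3ccccc3s2)c2cc(OC)c(OC)c(OC)c2)cc1F` gives 20100 nM. Compound 3 cannot be told apart from compound 1, with a 1.4-fold higher number from compound 1 to compound 3 (0.14 log units; within the scatter), but it is clearly weaker than compound 2, with a 9.5-fold higher number from compound 2 to compound 3 (0.98 log units; beyond the scatter).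

The next compound, compound 4 `COc1cc(N(Cc2ccc(F)cc2)C(=O)CSc2nc3ccccc3s2)cc(OC)c1OC`, differs from compound 3 on a saturated chain carbon bound to an amide-type nitrogen: 4-fluorophenyl in place of 3-fluoro-4-methoxyphenyl on a saturated chain carbon bound to an amide-type nitrogen. Put another way, 3-fluoro-4-methoxybenzyl gives way to 4-fluorobenzyl.

All three measured steps exchange a single group on an aromatic carbon, so they bear on this change only in part. The one clear gain, a 6.8-fold lower number from compound 1 to compound 2 (0.83 log units; beyond the scatter), came with the hydroxy of compound 2, and compound 4 carries no hydroxy. The exchange between azido and fluoro, seen in a 1.4-fold higher number from compound 1 to compound 3 (0.14 log units; within the scatter), made no difference beyond the scatter. Going by the values given here, no measured pair shows what losing the methoxy does, so the uncertainty is wide. The expected change is small and within the scatter, estimated as a 1.1-fold lower number from compound 3 to compound 4 (0.05 log units; within the scatter). In this assay, compound 4 is estimated at 18000 nM, with an expected range from 6000 nM to 55000 nM.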

Compound 4, half-maximal inhibitory concentration: 50800 nM
Estimate against measurement, compound 4: 2.8-fold (0.45 log units) below; measured number inside the range.
By their numbers in this assay, from the lowest: compound 2; then compounds 1 and 3 (each within the scatter of the next); then compound 4.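

In this assay this position proves sensitive to trimming: 4-fluorophenyl in place of 3-fluoro-4-methoxyphenyl on a saturated chain carbon bound to an amide-type nitrogen costs activity (a 2.5-fold higher number from compound 3 to compound 4 (0.40 log units; beyond the scatter)), a modest step beyond the scatter, whereas the earlier exchange of azido for fluoro moved nothing beyond it. Going by these compounds alone, the same trimmed group also falls short of the azido-bearing group (a 3.5-fold higher number from compound 1 to compound 4 (0.55 log units; beyond the scatter)) and, by the only large step, of the hydroxy-bearing group (a 24-fold higher number from compound 2 to compound 4 (1.38 log units; beyond the scatter)), so a change outside the single aromatic carbon varied earlier also shifts the number. Nothing available explains why this change raises the number.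

The change alters two things at once, since the methoxy goes and the fluoro no longer stands where it did, and the compounds shown cannot separate these two parts; a benzyl carrying methoxy alone or an unsubstituted benzyl would bear on that. Also open, from the compounds shown here alone, is whether an amine or a carboxylic acid in place of the hydroxy of compound 2 would keep its lead over the others.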